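This account rests on a few compounds, and the source may have more. Where it says the series, first, only, none or still open, it means among the compounds named here.

In a functional assay on MGC-803 cells (Homo sapiens) for antiproliferative activity, read by MTT assay, with a stated time of 72 h (a higher number here means a weaker inhibitor, a lower number a stronger inhibitor), compound 3 `CCCSc1nc(N/N=C/c2cccc(Cl)c2)c2nnn(Cc3ccccc3)c2n1` gives only a limit, > 64000 nM, and not a number. Within the data shown here, compound 2 `CCCSc1nc(N/N=C/c2ccccc2Cl)c2nnn(Cc3ccccc3)c2n1` gives 10900 nM, and the one measured step at this aryl position is an at least 5.8-fold higher number from compound 2 to compound 3 (0.76 log units; beyond the scatter), which swaps 2-chlorophenyl for 3-chlorophenyl. Compound 4 `CCCSc1nc(N/N=C/c2ccc(N(C)C)cc2)c2nnn(Cc3ccccc3)c2n1` carries 4-(dimethylamino)phenyl in place of 3-chlorophenyl on a carbon with a double bond to nitrogen. Compound 1 `C#CCSc1nc(N/N=C/c2ccc(N(C)C)cc2)c2nnn(Cc3ccccc3)c2n1` bears that same 4-(dimethylamino)phenyl with a different chain on sulfur and gives 7620 nM, so a measurable value is expected in this assay. An estimated step of an at least 6.4-fold lower number from compound 3 to compound 4 (0.80 log units; beyond the scatter) toward a lower number is expected, beyond the scatter. For compound 4 the estimate is 10000 nM, with an expected range of 3000 nM to 35000 nM.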

Compound 4, half-maximal inhibitory concentration: 13100 nM
Beside the measured number, compound 4's estimate is 1.3-fold (0.12 log units) below it; the measured number falls inside the stated range.
By their numbers in this assay, from the lowest: compounds 1, 2 and 4 (each within the scatter of the next). At a limit, above all of these: compound 3.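

In this assay, 4-(dimethylamino)phenyl gives a number where 3-chlorophenyl gave only a limit, with an at least 4.8-fold lower number from compound 3 to compound 4 (0.68 log units; beyond the scatter). Against 2-chlorophenyl the same group shows a 1.2-fold higher number from compound 2 to compound 4 (0.08 log units; within the scatter), so among these three aryl groups only 3-chlorophenyl stands apart. The chain on sulfur can now be read as well: ethyl in place of ethynyl on a saturated chain carbon bound to a sulfur gives a 1.7-fold higher number from compound 1 to compound 4 (0.24 log units; within the scatter).

Still open, as far as these compounds go, is how a plain phenyl, a 4-chlorophenyl or a carboxylic acid on the aryl ring would read in this assay. Also open, from the compounds shown here alone, is whether a longer chain on sulfur would give a step beyond the scatter.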